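Adding trifluoromethoxy to compound 3

This account rests on a few compounds, and the source may have more. Where it says the series, first, only, none or still open, it means among the compounds named here.

In a functional assay on NCI-H1993 cells (Homo sapiens) for inhibition, read by CCK-8 assay, with a stated time of 72 h (on this read-out higher numbers stand for weaker inhibition and lower numbers for stronger inhibition), compound 3 `c1ccc(-c2cnc3ncn(Cc4ccc5ncccc5c4)c3n2)cc1` gives 7490 nM and compound 2 `Nc1ccc(-c2cnc3ncn(Cc4ccc5ncccc5c4)c3n2)cc1` gives 4950 nM as its value, so the two lie within the scatter of each other. Compound 1 `Oc1nc2ncc(-c3ccccc3)nc2n1Cc1ccc2ncccc2c1` gives > 10000 nM as its reading, which is a limit and not a number.

Compound 4 `FC(F)(F)Oc1ccc(-c2cnc3ncn(Cc4ccc5ncccc5c4)c3n2)cc1` departs from compound 3 by a single change, trifluoromethoxy in place of hydrogen on an aromatic carbon, para to a large group (trifluoromethoxy in place of hydrogen on an aromatic carbon).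

Two measured steps offer guidance, although neither involves trifluoromethoxy. Replacing amino with hydrogen gives a 1.5-fold higher number from compound 2 to compound 3 (0.18 log units; within the scatter) as its result, and replacing hydroxy with hydrogen gives an at least 1.3-fold lower number from compound 1 to compound 3 (0.12 log units; that floor lies within the scatter) as a floor on its size. Neither goes beyond the scatter, so no step beyond the scatter is expected in this assay for this change either. The estimated 1.2-fold lower number from compound 3 to compound 4 (0.10 log units; within the scatter) is correspondingly small. Compound 4 is expected at 6000 nM as a central value, with an estimated range from 2000 nM to 15000 nM for the measurement.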

Compound 4, half-maximal inhibitory concentration: > 10000 nM
Compound 4 ended at the assay's limit (the forecaster's own chance of this, stated with the estimate: 25%); middle value at least 1.6-fold (0.22 log units) from the limit.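

In this assay compound 4 gives > 10000 nM, which is a limit and not a number. Until now this position had carried only hydrogen and amino, and trifluoromethoxy, the first larger group seen there, brings no lower number: it gives an at least 1.3-fold higher number from compound 3 to compound 4 (0.12 log units; that floor lies within the scatter) against hydrogen and an at least 2.0-fold higher number from compound 2 to compound 4 (0.30 log units; that floor lies within the scatter) against amino. Both steps are only floors, so their true size stays unknown, and the assay's ceiling now bounds what can be read at this position as well as at the hydroxy-bearing carbon of compound 1: the limit of > 10000 nM in this assay, at which 2 of the 4 values shown sit.

On these data alone, how far compound 4 lies past the limit remains open. Also open, as far as these compounds go, is whether a methoxy, a fluorine or a carboxylic acid on the same carbon would give a reading distinct from those of hydrogen and amino.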